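Swapping the amide aryl group for a methoxy-cinnamoyl chain

The source may hold more compounds than are shown below. What is called first, only, known or untested is meant among the compounds shown, and "the series" means these compounds.

Compound 1 `CN1[C@@H]2c3[nH]c4ccccc4c3C[C@H]1[C@H](C#N)N1[C@@H](CNC(=O)c3cccc(C(F)(F)F)c3)c3[nH]c4ccccc4c3C[C@@H]21`: 210 nM in a functional assay on A2780 cells (Homo sapiens) for cytotoxicity, read by MTT assay, with a stated time of 72 h; on this read-out lower numbers stand for stronger inhibition and higher numbers for weaker inhibition
Compound 2 `CN1[C@@H]2c3[nH]c4ccccc4c3C[C@H]1[C@H](C#N)N1[C@@H](CNC(=O)c3cc4ccccc4s3)c3[nH]c4ccccc4c3C[C@@H]21`: 20 nM in this assay

Compound 2 gives the lowest number of the two, the change being an 11-fold lower number from compound 1 to compound 2 (1.02 log units; beyond the scatter). Compound 3 `COc1ccc(/C=C/C(=O)NC[C@H]2c3[nH]c4ccccc4c3C[C@H]3[C@H]4c5[nH]c6ccccc6c5C[C@@H]([C@H](C#N)N23)N4C)cc1` differs from compound 2 by 2-(4-methoxyphenyl)ethenyl in place of 1-benzothiophen-2-yl on a carbonyl carbon. For the measured compounds named here, only that one step bears on this change, and it shows that the group on the carbonyl carbon can move the number a great deal. Since the new group is unlike either tested one, a loss of potency is expected, so the step of a 4.0-fold higher number from compound 2 to compound 3 (0.60 log units; beyond the scatter) is estimated. Compound 3 is expected to give 80 nM, within 25 nM to 300 nM.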

Compound 3, half-maximal inhibitory concentration: 860 nM
The estimate for compound 3 lay 11-fold (1.03 log units) below the measured number, outside the stated range (above it).
By their numbers in this assay, from the lowest: compound 2; then compound 1; then compound 3.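

In this assay, the step to the 2-(4-methoxyphenyl)ethenyl group is a 43-fold higher number from compound 2 to compound 3 (1.63 log units; beyond the scatter), and against the other aryl amide it is a 4.1-fold higher number from compound 1 to compound 3 (0.61 log units; beyond the scatter). Both steps lie beyond the scatter, so compound 3 is the weakest of the three, and a group on this carbonyl carbon can lose potency as well as gain it. Nothing available explains this order. Going by these compounds, whether the double bond or the methoxy group matters more stays open, since both enter together. On these data alone, a phenyl group carrying an amine or a carboxylic acid at this place also remains untested here.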